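Urea aryl exchange from compound 2 to compound 4

The source may hold more compounds than are shown below. What is called first, only, known or untested is meant among the compounds shown, and "the series" means these compounds.

Compound 2 `O=C(Nc1cccc(Cl)c1)Nc1cccc(CNc2nccnc2Cl)c1` is the reference point of this note. In a functional assay on HepG2 cells (Homo sapiens) for antiproliferative activity, read by MTT assay, with a stated time of 48 h (a higher number here means a weaker inhibitor, a lower number a stronger inhibitor), compound 2 gives 9140 nM, the lower of the two numbers shown; compound 1 `COc1ccccc1NC(=O)Nc1cccc(CNc2nccnc2Cl)c1` gives 13700 nM in this assay, and the step of a 1.5-fold lower number from compound 1 to compound 2 (0.18 log units; within the scatter) stays inside the scatter, so no real separation between the two can be claimed. Compound 3 `O=C(Nc1cccc(CNc2nccnc2Cl)c1)NC1CCCCC1` carries cyclohexyl on the same nitrogen. In this assay compound 3 gives > 40000 nM, which is a limit of the assay and not a number (the limit of > 40000 nM in this assay, at which 1 of the 3 values shown sits). The steps of an at least 2.9-fold higher number from compound 1 to compound 3 (0.46 log units; beyond the scatter) and an at least 4.3-fold higher number from compound 2 to compound 3 (0.64 log units; beyond the scatter) are the only ones beyond the scatter, and both mark the exchange of an aromatic ring for cyclohexyl on that nitrogen.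

Compound 4 `O=C(Nc1cccc(CNc2nccnc2Cl)c1)Nc1ccc(Cl)cc1Br` is not yet measured. Its change from compound 2 is 2-bromo-4-chlorophenyl in place of 3-chlorophenyl on an amide-type nitrogen. Going by the values given here, the one measured step that exchanges one aryl group for another, a 1.5-fold lower number from compound 1 to compound 2 (0.18 log units; within the scatter), was within the scatter, whereas the two steps beyond it involve cyclohexyl and so bear only loosely on an aryl-to-aryl swap. The expectation is therefore a step of a 1.0-fold lower number from compound 2 to compound 4 (0.01 log units; within the scatter) that does not leave the scatter. Compound 4 is accordingly estimated at 9000 nM in this assay, within a range from 3000 nM to 27000 nM.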

Compound 4, half-maximal inhibitory concentration: 6720 nM
The estimate for compound 4 lay 1.3-fold (0.13 log units) above the measured number; low and high end bracket the measured number.
By their numbers in this assay, from the lowest: compounds 4, 2 and 1 (each within the scatter of the next, the first and the last beyond it). At a limit, above all of these: compound 3.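

In this assay, the exchange of 3-chlorophenyl for 2-bromo-4-chlorophenyl on this urea nitrogen gives a 1.4-fold lower number from compound 2 to compound 4 (0.13 log units; within the scatter), so a larger, dihalogenated phenyl group is accepted here without a step that leaves the scatter. The step of a 2.0-fold lower number from compound 1 to compound 4 (0.31 log units; beyond the scatter) is the first aryl-to-aryl step on this nitrogen to lie beyond the scatter, though it is only modest, and the third aryl compound, compound 2, sits within the scatter of both ends, so the aryl groups shown span a shallow range with no clear tiers. The step of an at least 5.9-fold lower number from compound 3 to compound 4 (0.77 log units; beyond the scatter) again sets an aryl group apart from cyclohexyl on this nitrogen, but it gives only a bound, as compound 3 stands at a value that is a limit of the assay and not a number: the limit of > 40000 nM in this assay, at which 1 of the 4 values shown sits.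

Neither 2-bromophenyl nor 4-chlorophenyl stands among the compounds, so the contributions of the two halogens to the step cannot be separated. Also open, as far as these compounds go, is how this nitrogen would respond to a pyridyl ring, a phenyl group carrying a carboxylic acid or an amine, or a longer chain such as benzyl.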